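Bromo to chloro on the aryl ring of compound 3

This account rests on a few compounds, and the source may have more. Where it says the series, first, only, none or still open, it means among the compounds named here.

Measured in a functional assay on the whole organism (Abdomen, strain Swiss albino) with Mus musculus as the target, with stated times of 10 min and 5 min, at a dose of 15 mg/kg by the oral route; on this read-out lower numbers stand for a weaker effect and higher numbers for a stronger effect at the one dose given:
compound 1, `O=C1C2ON=C(c3cn(-c4ccccc4)nc3-c3ccccc3)C2C(=O)N1c1ccccc1`: 30.6%
compound 2, `CCOC(=O)c1onc(-c2cn(-c3ccccc3)nc2-c2ccc(OC)cc2)c1C(=O)OCC`: 11.4%
compound 3, `Brc1ccc(-c2nn(-c3ccccc3)cc2-c2cc(-c3ccccc3)on2)cc1`: 14.5%

Of the compounds shown here, three have numbers so far. Compound 3 and compound 2 lie within the scatter of each other, so nothing can be said about their order. Compound 1 stands above compound 3 by a gap beyond the scatter, and is the only one of the three that does. Within the data shown here, none of the measured pairs differs in a single place, so no step in this assay has yet been isolated from a single structural change.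

Compound 4, `Clc1ccc(-c2nn(-c3ccccc3)cc2-c2cc(-c3ccccc3)on2)cc1`, is not yet measured. It differs from compound 3 only by chloro in place of bromo on an aromatic carbon. Put one bond further out, the 4-bromophenyl of compound 3 becomes a 4-chlorophenyl in compound 4, para to a large group; nothing else in the molecule moves.

Among the measured compounds shown here, with no single-change step available for comparison, the expectation for this exchange is a step of no size beyond the scatter, in no particular direction. Compound 4 is expected to give about 14% in this assay, within a range from 4% to 26%. The expected step of a number 0.5 percentage points lower from compound 3 to compound 4 (within the scatter) therefore stays inside the usual scatter of this read-out.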

Compound 4, a percentage reported as activity, at one dose (the size of the read-out at that dose, not a potency): 1.58%
Estimate against measurement, compound 4: 12.4 percentage points above; the measured number lies below the stated range.
By their numbers in this assay, from the lowest: compounds 4, 2 and 3 (each within the scatter of the next, the first and the last beyond it); then compound 1.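

In this assay, the position para to a large group on the aryl ring of compound 3 proves sensitive to the identity of its halogen: the exchange of bromo for chloro gives a step (a number 12.9 percentage points lower from compound 3 to compound 4 (beyond the scatter)) that lies beyond the scatter, although the heavy-atom count is unchanged and neither group adds a ring, a hydrogen-bond donor or acceptor, or a net charge. Among these compounds, this is the first change isolated to a single place, so the earlier compounds could not show that a substitution this small, with the rest of the molecule fixed, can move this read-out beyond the scatter at the one dose given. The step shows only that the read-out moved, and nothing measured here accounts for it.

On these data alone, it remains open whether the trend extends beyond this pair of halogens, for instance to fluoro, an amine or a carboxylic acid at the same position. Also unresolved is whether the same exchange would produce a step of similar size and direction on the cores of compound 1 or compound 2.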